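Chlorofuran swap on the 4-methylphenyl member of the series

The source may report more compounds than this note shows. Statements on the series, on what has been measured and on what is new or still open speak of the compounds shown alone.

Measured so far in a functional assay on HCT-15 cells (Homo sapiens) for cytotoxicity, in the presence of a further agent that is not named here; on this read-out higher numbers stand for weaker inhibition and lower numbers for stronger inhibition
Compound 1 (`Cc1ccccc1-c1cc(-c2ccc(Cl)o2)cc(-c2ccsc2)n1`): 4630 nM
Compound 2 (`Clc1ccc(-c2cc(-c3ccc(Cl)o3)cc(-c3ccsc3)n2)cc1`): 5190 nM
Compound 3 (`Cc1ccc(-c2cc(-c3ccoc3)cc(-c3ccsc3)n2)cc1`): 44800 nM

Compound 3 has the highest number of the three, beyond the scatter from both compound 1 and compound 2. Compound 4 (`Cc1ccc(-c2cc(-c3ccc(Cl)o3)cc(-c3ccsc3)n2)cc1`) has 5-chlorofuran-2-yl in place of furan-3-yl on an aromatic carbon, opposite the ring nitrogen (5-chlorofuran-2-yl in place of furan-3-yl on an aromatic carbon). Going by the values given here, the only measured single-place step (a 1.1-fold higher number from compound 1 to compound 2 (0.05 log units; within the scatter)) exchanges 2-methylphenyl for 4-chlorophenyl and stays within the scatter. Among the compounds with values here, no measured step isolates the furan exchange, and no compound with 5-chlorofuran-2-yl yet carries 4-methylphenyl. Both compound 1 (4630 nM) and compound 2 (5190 nM) carry 5-chlorofuran-2-yl, so compound 4 is expected to sit near them. An expected step of an 8.1-fold lower number from compound 3 to compound 4 (0.91 log units; beyond the scatter) in this assay follows, beyond the scatter. Compound 4 is estimated at 5500 nM (range 2500 nM to 12000 nM).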

Compound 4, half-maximal inhibitory concentration: 7410 nM
For compound 4 the middle estimate is 1.3-fold (0.13 log units) below the measured one; the measured number falls inside the stated range.
By their numbers in this assay, from the lowest: compounds 1, 2 and 4 (each within the scatter of the next); then compound 3.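

Going by these compounds alone, the exchange of furan-3-yl for 5-chlorofuran-2-yl, opposite the ring nitrogen, now stands as a measured single-place step in this assay with a 6.0-fold lower number from compound 3 to compound 4 (0.78 log units; beyond the scatter) as its size, and it is the first step to isolate this position. With 5-chlorofuran-2-yl held in place, the aryl exchanges do not separate the compounds: methyl in place of chloro gives a 1.4-fold higher number from compound 2 to compound 4 (0.15 log units; within the scatter) and 4-methylphenyl in place of 2-methylphenyl gives a 1.6-fold higher number from compound 1 to compound 4 (0.20 log units; within the scatter) as its result. No measurement at hand bears on the reason for the furan step.

Within the data shown here, the single step changes both the chlorine and the furan attachment point, so furan-2-yl without chlorine would be needed to divide the two. As far as these compounds go, how an amine or a carboxylic acid would read out at this position also stays open.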